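Methylsulfonyl for methoxy: compound 1 to compound 3

The compounds below may be only part of what the source reports. "The series", "measured", "known", "first", "only" and "open" are said of these compounds alone.

- compound 1 `CCC(CC)O[C@@H]1C=C(C(=O)NOC)C[C@H](NC(=N)N)[C@H]1NC(C)=O` reads > 100000 nM
- compound 2 `CCC(CC)O[C@@H]1C=C(C(=O)NOCCCc2cc3ccccc3[nH]2)C[C@H](NC(=N)N)[C@H]1NC(C)=O` reads > 100000 nM

In an ADME assay on HEK-293T cells (Homo sapiens) for cytotoxicity, with a stated time of 48 h (on this read-out lower numbers stand for higher toxicity in this test and higher numbers for lower toxicity in this test), compound 1 gives > 100000 nM as a limit and not a number. Compound 2 gives > 100000 nM and this too is a limit. The evidence so far is the limit of > 100000 nM in this assay, at which 2 of the 2 values shown sit, and it gives no number to start from.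

Compound 3 `CCC(CC)O[C@@H]1C=C(C(=O)NS(C)(=O)=O)C[C@H](NC(=N)N)[C@H]1NC(C)=O` is not yet measured. It has methylsulfonyl in place of methoxy on an amide-type nitrogen on the core of compound 1. Among the compounds with values here, the one measured step is a step that the two limits leave unreadable from compound 1 to compound 2 and it concerns a different change, so it offers no size to carry over. No shift beyond the scatter is foreseen in this assay in either direction. The expected step is a number no higher from compound 1 to compound 3 (the limit leaves the size open) on this basis. Compound 3 is estimated at 100000 nM with an expected range from 40000 nM to 250000 nM and a further limit is the likeliest report.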

Compound 3, half-maximal cytotoxic concentration: > 100000 nM
Compound 3 ended at the assay's limit (the forecaster's own chance of this, stated with the estimate: 85%); the middle value lies on the limit itself.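

No step can be read between compound 1 and compound 3: in this assay both give limits, not numbers. Left open is whether any group on the amide-type nitrogen gives a numerical half-maximal cytotoxic concentration in this assay at all: the limit of > 100000 nM in this assay, at which 3 of the 3 values shown sit.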